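Changing the amine substituent on the benzyl ring of a styryl sulfone

The source may report more compounds than this note shows. Statements on the series, on what has been measured and on what is new or still open speak of the compounds shown alone.

Measured compounds and their values:
Compound 1, `COc1cc(OC)c(/C=C/S(=O)(=O)Cc2ccc(Cl)c(N)c2)c(OC)c1`, 10 nM.
Compound 2, `COc1cc(OC)c(/C=C/S(=O)(=O)Cc2ccc(F)c([N+](=O)[O-])c2)c(OC)c1`, 25000 nM.
Compound 3, `COC(=O)CNc1cc(CS(=O)(=O)/C=C/c2c(OC)cc(OC)cc2OC)ccc1OC`, 100 nM.

All three share a core in which a trimethoxyphenyl group is joined through a vinyl sulfone to a benzyl ring, and they differ in the substituents on that benzyl ring. Their numbers come from a functional assay on DU-145 cells (Homo sapiens) for cytotoxicity, read by trypan blue exclusion, with a stated time of 96 h; a higher number here means a weaker inhibitor, a lower number a stronger inhibitor. Compound 1 gives the lowest number, 10 nM, and compound 2 gives by far the highest, 25000 nM. Compound 3, with 100 nM, stands second highest of the three: its number is higher than that of compound 1 and far below that of compound 2, both gaps lying beyond the usual scatter.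

Compound 4, `COc1cc(OC)c(/C=C/S(=O)(=O)Cc2ccc(OC)c(NC(C)(C)C(=O)O)c2)c(OC)c1`, has not yet been measured. It differs from compound 3 in one place only:

1-carboxy-1-methylethyl in place of (methoxycarbonyl)methyl on a nitrogen on an aromatic ring

Among the measured compounds shown here, no pair of measured compounds shows what this kind of change does, so the expectation rests on compound 3 alone. Because compound 3 gives 100 nM, a number of the same order is expected for compound 4, with a step of a 2.0-fold higher number from compound 3 to compound 4 (0.30 log units; within the scatter) toward a somewhat higher number that may or may not exceed the scatter. Compound 4 is therefore estimated at 200 nM, within a range from 40 nM to 1500 nM.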

Compound 4, half-maximal inhibitory concentration: 150 nM
Estimate against measurement, compound 4: 1.3-fold (0.12 log units) above; the measured number falls inside the stated range.
By their numbers in this assay, from the lowest: compound 1; then compounds 3 and 4 (each within the scatter of the next); then compound 2.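

In this assay, the change on this nitrogen gives a 1.5-fold higher number from compound 3 to compound 4 (0.18 log units; within the scatter), so the two compounds cannot be told apart. Compound 3 alone showed only that a substituted nitrogen at this position is compatible with a value of 100 nM; this pair adds that the substituent can change from (methoxycarbonyl)methyl to 1-carboxy-1-methylethyl, where the entering group counts a hydrogen-bond donor and the leaving group none, with no difference beyond the usual scatter. No measurement at hand offers any explanation for this result.

The step alters two things at once, the end of the chain and the carbon attached to the nitrogen, so it cannot show whether each alone would leave the number in place or whether their separate effects offset each other; the methyl ester of 1-carboxy-1-methylethyl and a carboxymethyl group on the same nitrogen would separate the two. On these data alone, what an amide or a longer chain on this nitrogen would give also stays open, since compound 1 and compound 2 differ from this pair in more than one place and cannot answer it.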